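The compounds below may be only part of what the source reports. "The series", "measured", "known", "first", "only" and "open" are said of these compounds alone.

Of the compounds shown here, two have so far been measured in a functional assay (Pituitary gland cell) with Rattus norvegicus as the target; on this read-out lower numbers stand for an effect already at smaller amounts and higher numbers for an effect only at larger amounts of compound. Compound 1 `CC(C)(CC(=O)N[C@@H]1CCc2ccccc2N(Cc2ccc(-c3ccccc3-c3nn[nH]n3)cc2)C1=O)NCCO` gives 30 nM in this assay. Compound 2 `CC(C)(O)CNC(C)(C)CC(=O)N[C@@H]1CCc2ccccc2N(Cc2ccc(-c3ccccc3-c3nn[nH]n3)cc2)C1=O`, which carries a 1-hydroxy-1-methylethyl group in place of the hydroxymethyl group on a saturated chain carbon bound to an amine nitrogen, gives 10 nM. Among the compounds with values here, that single change produced a 3.0-fold lower number from compound 1 to compound 2 (0.48 log units; beyond the scatter), so compound 2 stands as the lower of the two numbers, with compound 1 as its only neighbour.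

Compound 3 `C[C@H](O)CCNC(C)(C)C(=O)N[C@@H]1CCc2ccccc2N(Cc2ccc(-c3ccccc3-c3nn[nH]n3)cc2)C1=O` has not yet been measured. It differs from compound 2 in one place: 1-((3-hydroxybutyl)amino)-1-methylethyl in place of 2-((2-hydroxy-2-methylpropyl)amino)-2-methylpropyl on a carbonyl carbon. The chain that leaves carries a 2-hydroxy-2-methylpropyl unit, the same kind of hydroxyl arrangement that compound 2 gained over compound 1; the chain that enters carries a 3-hydroxybutyl unit instead. Within the data shown here, only the step from compound 1 to compound 2 bears on this change, and it was modest. Because a 3.0-fold lower number from compound 1 to compound 2 (0.48 log units; beyond the scatter) followed the gain of that hydroxyl arrangement, and compound 3 gives it up again, the expected step is a 2.5-fold higher number from compound 2 to compound 3 (0.40 log units; beyond the scatter), a modest rise in the number. The estimate for compound 3 in this assay is therefore 25 nM, with a range from 8 nM to 80 nM.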

Compound 3, concentration for half-maximal effect: 50 nM
Compound 3: middle estimate off by 2.0-fold (0.30 log units), on the low side; the range from low to high includes it.
By their numbers in this assay, from the lowest: compound 2; then compounds 1 and 3 (each within the scatter of the next).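

In this assay, a 5.0-fold higher number from compound 2 to compound 3 (0.70 log units; beyond the scatter) shows that this position responds to more than the gain or loss of one hydroxyl arrangement: the 1-((3-hydroxybutyl)amino)-1-methylethyl group on the carbonyl carbon gives up much of what the 2-((2-hydroxy-2-methylpropyl)amino)-2-methylpropyl group had reached. Compound 3 is nevertheless not clearly apart from the compound with the shorter hydroxyethyl unit, as a 1.7-fold higher number from compound 1 to compound 3 (0.22 log units; within the scatter) lies within the scatter, so the two different side chains cannot be ranked on these numbers. This change also alters two things at once, the chain attached to the carbonyl carbon and the hydroxyl-bearing unit on the amine nitrogen, and no measurement here offers an explanation for the step.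

Still open is which of those two alterations accounts for the step, a question that a 3-hydroxybutyl unit on the 2-methylpropyl chain could help to separate. Also open, going by these compounds, is how the number would respond to a carboxylic acid in place of the hydroxyl group on the same unit.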